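Fluoro Addition on a Difluorophenyl Ring in Two Cores

The source may hold more compounds than are shown below. What is called first, only, known or untested is meant among the compounds shown, and "the series" means these compounds.

Compound 1 `Cc1cc(=O)n(-c2ccc(F)cc2)nc1C(=O)Nc1ccc(Oc2ncnc3ccsc23)c(F)c1`: 740 nM
Compound 2 `Cc1cc(=O)n(-c2ccc(F)c(F)c2)nc1C(=O)Nc1ccc(Oc2ncnc3ccsc23)c(F)c1`: 6900 nM
Compound 3 `Cc1cc(=O)n(-c2ccc(F)cc2)nc1C(=O)Nc1ccc(Oc2ncnc3sccc23)cc1`: 21000 nM

In a functional assay on MCF7 cells (Homo sapiens) for cytotoxicity, read by MTT assay, with a stated time of 72 h (on this read-out lower numbers stand for stronger inhibition and higher numbers for weaker inhibition), compound 1 gives 740 nM, the lowest of the three numbers. Compound 2 differs from it by a single change, (fluoro in place of hydrogen on an aromatic carbon), and in this assay compound 2 gives 6900 nM; that step reads a 9.3-fold higher number from compound 1 to compound 2 (0.97 log units; beyond the scatter). Compound 3 carries the other core, and the difference between the two cores is not broken down here; in this assay compound 3 gives 21000 nM, which is the highest of the three numbers and stands well apart from both compound 1 and compound 2.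

Compound 4 `Cc1cc(=O)n(-c2ccc(F)c(F)c2)nc1C(=O)Nc1ccc(Oc2ncnc3sccc23)cc1` has not been measured. Within the data shown here, it stands to compound 3 as compound 2 stands to compound 1: the change is fluoro in place of hydrogen on an aromatic carbon, and it is the same change, at the same place, as the one made from compound 1 to compound 2. Among the measured compounds shown here, the only guide to its size is that earlier step, so compound 4 is expected to move in the same direction, with a step of about a 4.8-fold higher number from compound 3 to compound 4 (0.68 log units; beyond the scatter), resting on the step from compound 1 to compound 2 a 9.3-fold higher number from compound 1 to compound 2 (0.97 log units; beyond the scatter) and the starting number of compound 3 21000 nM. Since compound 3 already sits high in this assay, the number for compound 4 may approach the range where only a limit is reported. Compound 4 is estimated at 100000 nM in this assay, with a likely range from 35000 nM to 300000 nM.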

Compound 4, half-maximal inhibitory concentration: 16100 nM
Compound 4: the middle estimate sits 6.2-fold (0.79 log units) above what was measured, outside the stated range (below it).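

On the core of compound 3, the change from 4-fluorophenyl to 3,4-difluorophenyl gives a 1.3-fold lower number from compound 3 to compound 4 (0.12 log units; within the scatter) in this assay, so the added fluoro leaves no readable change on this core. Among these compounds, the change therefore did not carry over from one core to the other, and a step read on the core of compound 1 gave no reliable guide to the step on the core of compound 3: the same change on two cores in this assay, a 9.3-fold higher number (0.97 log units; beyond the scatter) from compound 1 to compound 2 and a 1.3-fold lower number (0.12 log units; within the scatter) from compound 3 to compound 4, 12-fold (1.09 log units) apart, beyond the scatter of two such steps This shows only that the same change behaved differently in these two pairs; it does not show which of the differences between the core of compound 1 and the core of compound 3 goes with the gap, nor how the change would behave on any further core.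

The compounds shown leave open whether a chloro or methoxy group in place of the added fluoro would also give steps that differ between the two cores. Among the compounds shown here, they also leave open whether a compound that differs from compound 3 in only one part of the core would give a step like the one from compound 1 to compound 2 or like the one on the core of compound 3.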